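Aryl ring swap at the isoxazole: pyridyl replaces fluorophenyl

The source may report more compounds than this note shows. Statements on the series, on what has been measured and on what is new or still open speak of the compounds shown alone.

The series shares one core, varied only in the aromatic group attached to it. In an assay on a protein complex for positive allosteric modulation of Neuronal acetylcholine receptor; alpha4/beta2 (Homo sapiens) (a higher number here means a larger maximal response, a lower number a smaller maximal response), compound 1 `Fc1cccc(Cl)c1-c1cc(-c2cnn(C3CCNCC3)c2)on1` gives 60%, compound 2 `Fc1ccc(Cl)c(-c2cc(-c3cnn(C4CCNCC4)c3)on2)c1` gives 29% and compound 3 `Fc1cccc(-c2cc(-c3cnn(C4CCNCC4)c3)on2)c1Cl` gives 47%. Compound 3 thus stands second highest of the three: a number 13 percentage points lower from compound 1 to compound 3 (beyond the scatter) places it under compound 1, while a number 18 percentage points higher from compound 2 to compound 3 (beyond the scatter) places it above compound 2. The third measured step, a number 31 percentage points lower from compound 1 to compound 2 (beyond the scatter), is the largest in the set.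

Compound 4 `Clc1cnccc1-c1cc(-c2cnn(C3CCNCC3)c2)on1` is unmeasured. Its change from compound 3 is 3-chloropyridin-4-yl in place of 2-chloro-3-fluorophenyl on an aromatic carbon. All three measured steps concern 2-chloro-6-fluorophenyl, 2-chloro-5-fluorophenyl and 2-chloro-3-fluorophenyl, so they show that this assay is sensitive to the aromatic group on the core, with steps from modest to large. Going by the values given here, none of them involves a ring with a hetero atom, and none removes a fluorine, so no measured step bears directly on the move to 3-chloropyridin-4-yl. The expectation for compound 4 is therefore wide: a step of a number 9 percentage points lower from compound 3 to compound 4 (within the scatter) is estimated, downward but uncertain in size. For compound 4 the estimate in this assay is 38%, with a range from 18% to 62%.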

Compound 4, largest response reached (reported as efficacy), in percent of the reference or control that the assay uses: 50%
Compound 4: middle estimate off by 12 percentage points, on the low side; low and high end bracket the measured number.
By their numbers in this assay, from the lowest: compound 2; then compounds 3, 4 and 1 (each within the scatter of the next, the first and the last beyond it).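

In this assay, going by these compounds alone, the swap to 3-chloropyridin-4-yl is the first change here to put a hetero atom into the aromatic ring on the shared core, adding a hydrogen-bond acceptor and removing the fluorine, and it gives a number 3 percentage points higher from compound 3 to compound 4 (within the scatter). The same compound stays close to the top of the set, with a number 10 percentage points lower from compound 1 to compound 4 (within the scatter), yet it stands clearly apart from the lowest member, with a number 21 percentage points higher from compound 2 to compound 4 (beyond the scatter), so at this position next to the ring nitrogen the number depends on more than whether the ring is all carbon, and compound 4 groups with compound 1 and compound 3 rather than with compound 2. No data on hand account for why this ring change leaves the response where it is.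

The ring nitrogen and the loss of fluorine change together in this step, and a plain 2-chlorophenyl group or a fluorinated 3-chloropyridin-4-yl group would be needed to tell them apart. On these data alone, the role of the chlorine also stays open, since a pyridyl ring bearing a methyl or methoxy group in its place would test whether the halogen matters at all.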